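A few compounds are considered here, and "the series" means these few. Any claim that something is new, unique, unknown or untested is made for them only; others in the source may bear on it.

Measured compounds:
Compound 1, `CC(C)(C)C1=NN(c2cccc(Cl)c2)C(c2ccc(O)cc2)C1`, in an assay on isolated protein for inhibition of protein kinase C zeta type (Homo sapiens), with a stated time of 4 min (on this read-out higher numbers stand for weaker inhibition and lower numbers for stronger inhibition), gives 5200 nM.
Compound 2, `CC(C)(C)C1=NN(c2ccccc2F)C(c2ccc(O)cc2)C1`, in this assay gives "not determined" (no result reported).
Compound 3, `CC(C)(C)C1=NN(c2ccc(Cl)cc2Cl)C(c2ccc(O)cc2)C1`, in this assay gives "not determined" (no result reported).

Compound 3 therefore stands without a number in this assay, and compound 2 is in the same position, so compound 1 is the only one of the three with a result. The step to compound 4, `CC(C)(C)C1=NN(c2ccc(F)c(Cl)c2)C(c2ccc(O)cc2)C1`, is 3-chloro-4-fluorophenyl in place of 2,4-dichlorophenyl on an amine nitrogen in a ring. Among the compounds with values here, with no measured pair differing in one place, there is nothing to show how large such a change would be, so the expectation is a step no larger than the scatter, in no particular direction, anchored on the one number available for compound 1. Compound 4 is expected to give about 5000 nM in this assay, within a range from 1500 nM to 20000 nM.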

Compound 4, half-maximal inhibitory concentration: 900 nM
Beside the measured number, compound 4's estimate is 5.6-fold (0.74 log units) above it, outside the stated range (below it).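

The step from compound 3 to compound 4 cannot be read, since compound 3 has no number in this assay. Still, fluoro in place of hydrogen on an aromatic carbon gives a 5.8-fold lower number from compound 1 to compound 4 (0.76 log units; beyond the scatter), so inhibition responds to a change as small as one atom on the aromatic group carried by the amine nitrogen in the ring. No measurement shown here explains this gain. From the compounds shown here alone, it remains open whether fluoro would do the same without the chloro group, and how a methoxy group or an amine would fare in its place.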